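The source may report more compounds than this note shows. Statements on the series, on what has been measured and on what is new or still open speak of the compounds shown alone.

For the measured compounds named here, in a functional assay on PANC-1 cells (Homo sapiens) for antiproliferative activity, read by MTT assay, with a stated time of 48 h (a lower number here means that less compound is needed, a higher number that more compound is needed for the effect), compound 2 (`COc1ccccc1-n1c(SCC(=O)Nc2nc3ccc(C)cc3s2)nc2c(c1=O)SCC2`) gives 230 nM and stands lowest of the two numbers so far, while compound 1 (`Cc1ccc2nc(NC(=O)CSc3nc4c(c(=O)n3-c3ccc(F)cc3)SCC4)sc2c1`) gives 4870 nM as its only neighbour. Next, compound 3 (`Cc1ccc2nc(NC(=O)CSc3nc4c(c(=O)n3Cc3ccccc3)SCC4)sc2c1`) carries benzyl in place of 2-methoxyphenyl on an aromatic nitrogen. Going by the values given here, the one measured step at this place (a 21-fold lower number from compound 1 to compound 2 (1.33 log units; beyond the scatter)) is large, yet it involves no benzyl, so a moderate step beyond the scatter is expected in this assay, towards a higher number. The estimated step is (a 5.2-fold higher number from compound 2 to compound 3 (0.72 log units; beyond the scatter)). For compound 3 the estimate is 1200 nM as a middle, with an expected range (250 nM to 6000 nM).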

Compound 3, half-maximal effective concentration: > 10000 nM
Compound 3: no number, only a limit; the forecaster's own chance of this, stated with the estimate: 5%; middle value at least 8.3-fold (0.92 log units) away from the limit.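

In this assay compound 3 gives only a limit, > 10000 nM, not a number: the limit of > 10000 nM in this assay, at which 1 of the 3 values shown sits. Benzyl on the aromatic nitrogen gives an at least 43-fold higher number from compound 2 to compound 3 (1.63 log units; beyond the scatter) and an at least 2.0-fold higher number from compound 1 to compound 3 (0.31 log units; beyond the scatter), so it ranks behind both 2-methoxyphenyl and 4-fluorophenyl at this position. For the compounds shown here, the earlier pair showed only that the two aryl groups differ, whereas this change shows that benzyl is not tolerated as a replacement for either. The compounds shown leave open whether 2-methoxybenzyl or unsubstituted phenyl on this nitrogen would keep the low number of compound 2. The full size of both new steps also remains unread.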